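A few compounds are considered here, and "the series" means these few. Any claim that something is new, unique, unknown or untested is made for them only; others in the source may bear on it.

Of the compounds shown here, three have been measured in a functional assay on NCI-H23 cells (Homo sapiens) for inhibition, read by sulforhodamine B assay, with a stated time of 48 h; a higher number here means a weaker inhibitor of growth, a lower number a stronger inhibitor of growth.
Compound 1, `COc1cc(OC)cc(-c2ccc(-c3ccc(C(=N)N)c(F)c3)s2)c1`, gave 1430 nM.
Compound 2, `N=C(N)c1ccc(-c2ccc(-c3ccc(Cl)cc3)s2)cc1F`, gave 1150 nM.
Compound 3, `N=C(N)c1ccc(-c2ccc(-c3ccc(Cl)cc3)s2)cc1`, gave 190 nM.

Compound 1 and compound 2 differ in their cores; the difference between the two cores is not broken down here, and their two values lie within the usual scatter of each other. From compound 2 to compound 3 a single change is made, (hydrogen in place of fluoro on an aromatic carbon), and it gave a 6.1-fold lower number from compound 2 to compound 3 (0.78 log units; beyond the scatter). Compound 4, `COc1cc(OC)cc(-c2ccc(-c3ccc(C(=N)N)cc3)s2)c1`, carries the same change relative to compound 1, (hydrogen in place of fluoro on an aromatic carbon), which is the second time this change occurs among these compounds. Resting on a 6.1-fold lower number from compound 2 to compound 3 (0.78 log units; beyond the scatter), compound 4 is expected to give a step of about the same size, a 5.5-fold lower number from compound 1 to compound 4 (0.74 log units; beyond the scatter). A single prior example leaves the size uncertain. Compound 4 is estimated at 260 nM, with an expected range from 100 nM to 700 nM.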

Compound 4, concentration for 50% growth inhibition: 1920 nM
Beside the measured number, compound 4's estimate is 7.4-fold (0.87 log units) below it; the measured number lies above the stated range.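

Hydrogen in place of fluoro on the aromatic carbon gave a 1.3-fold higher number from compound 1 to compound 4 (0.13 log units; within the scatter), so in this assay the change did not carry over with the same size from one core to the other: the same change on two cores in this assay, a 6.1-fold lower number (0.78 log units; beyond the scatter) from compound 2 to compound 3 and a 1.3-fold higher number (0.13 log units; within the scatter) from compound 1 to compound 4, 8.1-fold (0.91 log units) apart, beyond the scatter of two such steps

In these two pairs the size of the step went with the core, and a step read on one core was no guide to the other. Going by these compounds alone, with only two pairs, this does not show which part of the cores accounts for the gap, or how the change would behave on a third core.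

The compounds shown leave open how a methyl group or an amine on the same aromatic carbon would behave on each core. They also leave open whether the two cores would part in the same way in another cell line.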